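Side-chain extension from compound 3 to compound 4

The source may hold more compounds than are shown below. What is called first, only, known or untested is meant among the compounds shown, and "the series" means these compounds.

In an in vitro ADME assay on microsomes from liver (Mus musculus) for metabolic stability, read by LC-MS (on this read-out higher numbers stand for a longer-lived compound and lower numbers for a shorter-lived compound), compound 1 `CN/C(=N\C1=NC(=O)C(=O)N1C(C)C)Nc1ccc(Cl)c(Cl)c1` gives > 1 h, which is a limit. Compound 2 `CC(C)N1C(=O)C(=O)N=C1/N=C(/Nc1ccc(Cl)c(Cl)c1)NC(C)(C)C` gives > 1 h, also a limit. Compound 3 `CC(C)N1C(=O)C(=O)N=C1/N=C(\NCCN(C)C)Nc1ccc(Cl)c(Cl)c1` gives > 1 h, likewise a limit, and the series offers only (the limit of > 1 h in this assay, at which 3 of the 3 values shown sit).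

Compound 4 `CC(C)N1C(=O)C(=O)N=C1/N=C(\NCCCCN1CCCC1)Nc1ccc(Cl)c(Cl)c1` differs from compound 3 as follows: 2-(pyrrolidin-1-yl)ethyl in place of dimethylamino on a saturated chain carbon, two bonds along the chain from an amine nitrogen, on a saturated chain carbon, two bonds along the chain from an amine nitrogen.

The measured changes at this side chain, a step that the two limits leave unreadable from compound 1 to compound 3 and a step that the two limits leave unreadable from compound 2 to compound 3, give no readable size, so neither sets a direction. No change beyond the scatter is therefore expected in this assay, and the expected step is a step that the limit leaves unreadable from compound 3 to compound 4. The estimated half-life of compound 4 is 1.2 h, with an expected range of 0.5 h to 2.4 h.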

Compound 4, half-life: > 1 h
Compound 4: only a limit was reported (the forecaster's own chance of this, stated with the estimate: 60%); the middle value is on the limit's open side.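

The steps from compound 1, compound 2 and compound 3 to compound 4 cannot be read in this assay, since every value is a limit: the limit of > 1 h in this assay, at which 4 of the 4 values shown sit.

As far as these compounds go, how long these four compounds actually last, and whether their side chains differ in half-life at all, remains open.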